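The compounds below may be only part of what the source reports. "The series", "measured", "known", "first", "only" and "open" are said of these compounds alone.

Of the compounds shown here, three sharing one core have been tested in an assay on isolated protein for inhibition of RAC-alpha serine/threonine-protein kinase (Homo sapiens), tested at 30 uM; a lower number here means less inhibition, a higher number more inhibition at the concentration tested (going by the name of the read-out). Compound 1 `c1ccc(Sc2ncnc3[nH]cnc23)cc1` gives 0%. Compound 2 `Cn1cnc2c(Sc3ccccc3)ncnc21` gives 0% in this assay, and compound 3 `Cn1cnc2c(Sc3ccc(F)cc3)ncnc21` gives 0% in this assay. Compound 2 stands level with both of them: no change at the digits printed from compound 1 to compound 2 (within the scatter) and no change at the digits printed from compound 2 to compound 3 (within the scatter). Compound 4 `CSc1ccc(-c2nc3c(Sc4ccccc4)ncnc3n2C)cc1` has not yet been measured; it differs from compound 2 by 4-(methylsulfanyl)phenyl in place of hydrogen on an aromatic carbon. Among the measured compounds shown here, neither measured step resembles this change, one being a methyl on a ring nitrogen, the other a fluoro on a ring carbon, and both were flat, so there is no example of what this added group does. With every measured compound showing no inhibition, the expectation for compound 4 in this assay is a step of a number 5 percentage points higher from compound 2 to compound 4 (within the scatter), leaving it at an estimated 5% within 0% to 35%.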

Compound 4, a percentage reported as inhibition, at one concentration (the size of the read-out at that concentration, not a potency): 5%
For compound 4 middle estimate and measured number coincide at the digits printed, within the range that was stated.
By their numbers in this assay, from the lowest: compounds 1, 2, 3 and 4 (each within the scatter of the next).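

In this assay, 4-(methylsulfanyl)phenyl in place of hydrogen on the aromatic carbon between two ring nitrogen atoms gives a number 5 percentage points higher from compound 2 to compound 4 (within the scatter) and so adds the first extra ring to this series without taking inhibition beyond the scatter. At this position, then, a substituent of 8 heavy atoms does not produce a clear gain at the concentration tested. No available evidence accounts for this result. Still open, on these data alone, is whether an amine or a carboxylic acid on the added phenyl ring, or a longer chain in place of its methylsulfanyl group, would change inhibition.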